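Swapping the Hydrazone Aryl Group on a Shared Core

A few compounds are considered here, and "the series" means these few. Any claim that something is new, unique, unknown or untested is made for them only; others in the source may bear on it.

Compound 1, `CCCSc1nc(N/N=C/c2cccs2)c2nnn(Cc3ccccc3)c2n1`: in a functional assay on ECa-109 cells (Homo sapiens) for antiproliferative activity, read by MTT assay, with a stated time of 72 h (on this read-out lower numbers stand for stronger inhibition and higher numbers for weaker inhibition), compound 1 gives > 64000 nM, which is a limit of the assay.
Compound 2, `CCCSc1nc(N/N=C(\C)c2ccc(O)cc2)c2nnn(Cc3ccccc3)c2n1`: in this assay compound 2 gives 32500 nM.
Compound 3, `CCCSc1nc(N/N=C/c2cccc(Cl)c2)c2nnn(Cc3ccccc3)c2n1`: in this assay compound 3 gives > 64000 nM, which is a limit of the assay.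

Compound 3 therefore stands at the limit of > 64000 nM in this assay, at which 2 of the 3 values shown sit, and no number is known for it. Compound 4, `CCCSc1nc(N/N=C(\C)c2ccccc2O)c2nnn(Cc3ccccc3)c2n1`, differs from compound 3 by a group of 10 heavy atoms (8 carbon, 1 nitrogen, 1 oxygen; one six-membered aromatic ring of carbon only) in place of a group of 9 heavy atoms (7 carbon, 1 nitrogen, 1 chlorine; one six-membered aromatic ring of carbon only), on a nitrogen on an aromatic ring. Of the measured steps, an at least 1.9-fold higher number from compound 2 to compound 3 (0.29 log units; that floor lies within the scatter) is closest in kind, since it runs in the opposite direction between groups of the same sort. The step of an at least 1.9-fold lower number from compound 1 to compound 2 (0.29 log units; that floor lies within the scatter) points the same way, and a step that the two limits leave unreadable from compound 1 to compound 3 gives no size. On this basis compound 4 is expected to sit near compound 2 rather than at the limit, an expected step of an at least 1.4-fold lower number from compound 3 to compound 4 (0.15 log units; that floor lies within the scatter) in this assay, though the floor of the measured steps lies within the scatter, so a limit for compound 4 remains quite possible. The estimated value for compound 4 is 45000 nM, with a range from 20000 nM to 100000 nM.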

Compound 4, half-maximal inhibitory concentration: 11100 nM
Beside the measured number, compound 4's estimate is 4.1-fold (0.61 log units) above it; the measured number lies below the stated range.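

For the compounds shown here, for the first time in this set, a change to this group can be read as a number: 2-hydroxyphenyl in place of 4-hydroxyphenyl on a carbon with a double bond to nitrogen gives a 2.9-fold lower number from compound 2 to compound 4 (0.47 log units; beyond the scatter), so in this assay the read-out depends on where the hydroxyl stands on the ring and not only on its presence. Against the two compounds without a hydroxyl, the difference now clears the scatter, which neither earlier floor did: an at least 5.7-fold lower number from compound 3 to compound 4 (0.76 log units; beyond the scatter), and an at least 5.7-fold lower number from compound 1 to compound 4 (0.76 log units; beyond the scatter). Both of these steps are floors and not sizes, because compound 1 and compound 3 each rest on a limit: the limit of > 64000 nM in this assay, at which 2 of the 4 values shown sit.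

As far as these compounds go, it remains open how much of those two floors belongs to the hydroxyl and how much to the methyl on the carbon with a double bond to nitrogen, which compound 4 carries and compound 1 and compound 3 do not. Also open, from the compounds shown here alone, is what 3-hydroxyphenyl would give at this place, or a methoxy or an amine in place of the hydroxyl.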